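Three Inactive Quinazoline-Type Anilines and a Predicted Fourth

The source may hold more compounds than are shown below. What is called first, only, known or untested is meant among the compounds shown, and "the series" means these compounds.

Measured compounds:
compound 1, `Fc1cccc(-c2nc(Nc3ccccc3)c3ccccc3n2)c1`: > 50000 nM
compound 2, `Fc1ccc2nc(-c3ccccc3)nc(Nc3ccccc3)c2c1`: > 50000 nM
compound 3, `Fc1cccc(-c2nc(Nc3ccccc3Cl)c3cc(F)ccc3n2)c1`: > 50000 nM

In a functional assay on HT29-AK cells (Homo sapiens) for cytotoxicity, read by MTT assay, with a stated time of 48 h (on this read-out higher numbers stand for weaker inhibition and lower numbers for stronger inhibition), compound 1 returns only a limit, > 50000 nM. Compound 2 likewise returns only a limit, > 50000 nM, in this assay. Compound 3 stands at the same point: its result in this assay is a limit, > 50000 nM, and no number. For the measured compounds named here, all three values sit at the limit of > 50000 nM in this assay, at which 3 of the 3 values shown sit, so no step between measured compounds can be sized.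

Compound 4, `Nc1cccc(Nc2nc(-c3cccc(F)c3)nc3ccc(F)cc23)c1`, has not been measured. It differs from compound 3 by 3-aminophenyl in place of 2-chlorophenyl on a nitrogen on an aromatic ring.

With every measured value a limit, the step of a number no higher from compound 3 to compound 4 (the limit leaves the size open) is expected to be none beyond the scatter. Compound 4 is therefore expected to give 50000 nM, within 10000 nM to 150000 nM, most likely again as a limit in this assay.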

Compound 4, half-maximal inhibitory concentration: > 50000 nM
Compound 4 was reported as a limit; the forecaster's own chance of this, stated with the estimate: 70%; the middle value lies on the limit itself.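

For compound 4 the limit > 50000 nM is all that is reported. No step from compound 3 to compound 4 can be read, since every value shown sits at one limit: the limit of > 50000 nM in this assay, at which 4 of the 4 values shown sit.

Going by these compounds, whether any change to the shared core would give a number rather than a limit stays open.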